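A few compounds are considered here, and "the series" means these few. Any claim that something is new, unique, unknown or untested is made for them only; others in the source may bear on it.

Values in an assay on cells for displacement of a labelled ligand from adenosine receptor A1 (Homo sapiens), read by scintillation counting, with a stated time of 120 min, tested at 1 uM (a lower number here means less inhibition, a higher number more inhibition at the concentration tested (going by the name of the read-out)), for the measured compounds:

compound 1 `O=C(Nc1nccn2cc(-c3ccccc3)nc12)c1ccco1`: 25%
compound 2 `O=C(Nc1nccn2cc(-c3ccccc3)nc12)c1cccnc1`: 24%
compound 3 `O=C(Nc1nc(-c2ccccc2)cn2cc(-c3ccccc3)nc12)c1ccc(Cl)cc1`: 1%

Compound 3 stands lowest of the three numbers. Its nearest neighbour is compound 2, which lies higher by a gap beyond the scatter; compound 1 lies furthest, also higher beyond the scatter.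

Compound 4 `O=C(Nc1nc(-c2ccccc2)cn2cc(-c3ccccc3)nc12)c1cccnc1` differs from compound 3 in one place: pyridin-3-yl in place of 4-chlorophenyl on a carbonyl carbon.

Within the data shown here, only one measured step touches the carbonyl substituent, a number 1 percentage points lower from compound 1 to compound 2 (within the scatter), and it swaps furan-2-yl for pyridin-3-yl rather than 4-chlorophenyl for pyridin-3-yl. Among the measured compounds shown here, no measured pair isolates the change from 4-chlorophenyl to pyridin-3-yl, and compounds 1 and 2 carry a core that differs from the core of compound 3, so their values cannot be read as a guide to compound 4 beyond showing that pyridin-3-yl on the carbonyl carbon gave a number near that of furan-2-yl in this assay. The step to compound 4 is therefore expected to stay within the scatter, a number 5 percentage points higher from compound 3 to compound 4 (within the scatter), with no direction asserted.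

For compound 4 the estimated value in this assay is 6%, with a range from -6% to 22%.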

Compound 4, a percentage reported as inhibition, at one concentration (the size of the read-out at that concentration, not a potency): 11%
Estimate against measurement, compound 4: 5 percentage points below; low and high end bracket the measured number.
By their numbers in this assay, from the lowest: compounds 3 and 4 (each within the scatter of the next); then compounds 2 and 1 (each within the scatter of the next).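

In this assay, the carbonyl substituent on the core of compound 3 now has its own measured pair: a number 10 percentage points higher from compound 3 to compound 4 (within the scatter) for pyridin-3-yl in place of 4-chlorophenyl. This agrees with the step on the core of compound 1, a number 1 percentage points lower from compound 1 to compound 2 (within the scatter), so on both cores the two swaps shown at this place stay within the scatter, although they involve different leaving groups. The new pair also gives a first reading of a second place, where phenyl in place of hydrogen on an aromatic carbon, with pyridin-3-yl held on the carbonyl carbon, gives a number 13 percentage points lower from compound 2 to compound 4 (beyond the scatter) as the only step shown beyond the scatter, and no supporting evidence bears on these results.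

As far as these compounds go, the phenyl step is seen with pyridin-3-yl alone, so whether it carries over to furan-2-yl or 4-chlorophenyl on the carbonyl carbon stays open, as compound 1 and compound 3 differ in more than one place. Also open, from the compounds shown here alone, is how an aliphatic amine or a carboxylic acid on the carbonyl carbon, or a methyl group in place of that phenyl, would read at this single concentration.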